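Thiourea compound 1 and its 3-cyanophenyl counterpart

This account rests on a few compounds, and the source may have more. Where it says the series, first, only, none or still open, it means among the compounds named here.

Measured so far:
- compound 1 `CC1(C)CC(NC(=S)NCc2ccccc2)c2cc(F)ccc2O1`: 27000 nM
- compound 2 `CC1(C)CC(NC(=O)Nc2cccc(Cl)c2)c2cc(Br)ccc2O1`: 69000 nM
- compound 3 `O=[N+]([O-])c1ccc(NC(=S)NCc2cccc(Cl)c2)cc1`: 27000 nM

All three values come from a functional assay on U-373MG ATCC cells (Homo sapiens) for inhibition, read by MTT assay, with a stated time of 72 h; on this read-out higher numbers stand for weaker inhibition and lower numbers for stronger inhibition. On this read-out compound 1 gives 27000 nM, level with compound 3 at 27000 nM, and the two together hold the lowest number of the set. Compound 2 gives 69000 nM, a higher number that stands beyond the scatter from both, and so weaker inhibition.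

The next compound to be read is compound 4 `CC1(C)CC(NC(=S)Nc2cccc(C#N)c2)c2cc(F)ccc2O1`. It keeps the core of compound 1 and carries 3-cyanophenyl in place of benzyl on an amide-type nitrogen.

Within the data shown here, no two measured compounds differ in one place only, so the data show no direct size for this change and no direction for it. The expectation rests only on the small spread of the set, which runs from compound 1 at 27000 nM to compound 2 at 69000 nM. In this assay a shift beyond the scatter is not expected, and neither direction is favoured.

The estimated step is a 1.1-fold lower number from compound 1 to compound 4 (0.03 log units; within the scatter).

For compound 4 the expected value is 25000 nM, with an estimated range of 9000 nM to 70000 nM.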

Compound 4, half-maximal inhibitory concentration: 30000 nM
Compound 4: middle estimate off by 1.2-fold (0.08 log units), on the low side; the measured number falls inside the stated range.
By their numbers in this assay, from the lowest: compounds 1, 3 and 4 (each within the scatter of the next); then compound 2.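

In this assay, among these compounds, compound 1 and compound 4 form the first pair that differs in one place only, so this change can now be read directly: 3-cyanophenyl in place of benzyl on an amide-type nitrogen gives a 1.1-fold higher number from compound 1 to compound 4 (0.05 log units; within the scatter). With the thiocarbonyl carbon as the other neighbour of that nitrogen and the core of compound 1 held constant, the exchange of these two aromatic groups leaves no readable difference on this read-out. The nitrile enters together with the change from benzyl to 3-cyanophenyl, so this single pair gives the size of the whole exchange and not a separate contribution from either part; no supporting measurement bears on why the step is this small.

Still open, going by these compounds, is how a plain phenyl or a longer chain such as phenethyl would read at this nitrogen, which would help separate the nitrile from the rest of the exchange. Also open, on these data alone, is whether an aminomethyl or carboxylic acid group on the aromatic ring would move the number beyond the scatter.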